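This account rests on a few compounds, and the source may have more. Where it says the series, first, only, none or still open, it means among the compounds named here.

Working notes on the series. Compound 1 `O=CN1CCN(c2ccc(Cl)cc2)C1=S` carries the shared core with a 4-chlorophenyl on one ring nitrogen; in a functional assay on UO-31 cells (Homo sapiens) for inhibition, read by sulforhodamine B assay, with a stated time of 48 h (on this read-out higher numbers stand for weaker inhibition of growth and lower numbers for stronger inhibition of growth), compound 1 gives "not determined" (no result reported), so no result is reported for it. Compound 3 `O=CN1CCN(C(=O)c2ccco2)C1=S` carries the furoyl group on that nitrogen and a formyl group on the other; in this assay compound 3 gives 4500 nM. Among the compounds with values here, compound 2 `N#C/C(=C\N1CCN(C(=O)c2ccco2)C1=S)C(N)=O` keeps the furoyl group but replaces the formyl group with the cyano-acrylamide arm; in this assay compound 2 gives 23500 nM, the highest of the two numbers known, compound 3 sitting beyond the scatter below it. Compound 4 `N#C/C(=C\N1CCN(C(=O)c2ccco2)C1=S)C(=O)Nc1ccc(Cl)cc1` differs from compound 2 in one place: 4-chlorophenyl in place of hydrogen on an amide-type nitrogen. Within the data shown here, with no step between measured compounds available for this change, the expectation rests on compound 2 alone, and the step from compound 2 to compound 4 is estimated to be a modest lowering of the number, a 2.4-fold lower number from compound 2 to compound 4 (0.37 log units; beyond the scatter), not far beyond the scatter. Compound 4 is accordingly expected to give 10000 nM in this assay, within a range of 2500 nM to 40000 nM.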

Compound 4, concentration for 50% growth inhibition: 12000 nM
The estimate for compound 4 lay 1.2-fold (0.08 log units) below the measured number, and the stated range covers the measured number.
By their numbers in this assay, from the lowest: compound 3; then compounds 4 and 2 (each within the scatter of the next).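

In this assay, placing 4-chlorophenyl in place of hydrogen on an amide-type nitrogen gives a 2.0-fold lower number from compound 2 to compound 4 (0.29 log units; within the scatter), the first step read at this position. The amide hydrogen of compound 2 can therefore give way to this aromatic group with no difference beyond the scatter, so the large group leaves the number of the cyano-acrylamide series where it was. Nothing measured here accounts for this result.

Still open, from the compounds shown here alone, is whether another group on this nitrogen, such as an unsubstituted phenyl, a longer alkyl chain or a chain ending in a carboxylic acid, would move the number beyond the scatter. Also open, going by these compounds, is whether 4-chlorophenyl on this nitrogen would read the same with another group in place of the furoyl group.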